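Shortening the Hydroxycarbamoyl Chain of Compound 1

This account rests on a few compounds, and the source may have more. Where it says the series, first, only, none or still open, it means among the compounds named here.

Measured in a functional assay on CNE-2 cells (Homo sapiens) for inhibition, read by MTT assay, with a stated time of 72 h; on this read-out higher numbers stand for weaker inhibition and lower numbers for stronger inhibition:
- compound 1 `Nc1ncnc2c1c(-c1cnc3[nH]ccc3c1)nn2CCCCCCCCC(=O)NO`: 2270 nM
- compound 2 `Nc1nc2cc(-c3nn(CCCC(=O)NO)c4ncnc(N)c34)ccc2o1`: > 50000 nM (a limit)

Compound 2 gives only a limit, > 50000 nM. Going by the values given here, compound 1, at 2270 nM, therefore holds the only true number in this assay. Compound 3 `Nc1ncnc2c1c(-c1cnc3[nH]ccc3c1)nn2CCCCCCC(=O)NO` carries a shorter chain than compound 1: hydroxycarbamoyl in place of 2-(hydroxycarbamoyl)ethyl on a saturated chain carbon, six bonds along the chain from an aromatic nitrogen. Among the compounds with values here, no measured pair shows what such a change does, so only a small move, in neither direction beyond the scatter, is expected: a 1.1-fold lower number from compound 1 to compound 3 (0.05 log units; within the scatter). Compound 3 is estimated at 2000 nM, with an expected range of 500 nM to 8000 nM.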

Compound 3, half-maximal inhibitory concentration: 19500 nM
Compound 3: the middle estimate sits 9.8-fold (0.99 log units) below what was measured; the whole stated range lies below it.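

In this assay, the chain position proves sensitive to length: putting hydroxycarbamoyl in place of 2-(hydroxycarbamoyl)ethyl gives an 8.6-fold higher number from compound 1 to compound 3 (0.93 log units; beyond the scatter). Going by these compounds alone, this is the only step that can be read here, and it shows that shortening the chain on this core weakens inhibition. Compound 2 differs from compound 1 in more than one place and gives only a limit: the limit of > 50000 nM in this assay, at which 1 of the 3 values shown sits. On these data alone, whether a longer chain would restore or further strengthen inhibition stays open, as does the effect of a carboxylic acid in place of the hydroxycarbamoyl end.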